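The source may report more compounds than this note shows. Statements on the series, on what has been measured and on what is new or still open speak of the compounds shown alone.

Measured so far: compound 1 `COC(=O)c1ccc(/C=C/C(=O)c2cc(OC)ccc2OC)cc1` gives 4850 nM; compound 2 `COc1ccc(OC)c(C(=O)/C=C/c2ccc(C(=O)OCc3ccccc3)cc2)c1` gives 18000 nM. Both come from a functional assay on PC-3 cells (Homo sapiens) for cytotoxicity, read by MTT assay, with a stated time of 72 h; on this read-out higher numbers stand for weaker inhibition and lower numbers for stronger inhibition.

Among the measured compounds shown here, compound 2 stands at the highest of the two numbers; its nearest neighbour is compound 1, and the only measured step, a 3.7-fold higher number from compound 1 to compound 2 (0.57 log units; beyond the scatter), is the one that separates them. It shows that enlarging the ester group from hydrogen to phenyl on a saturated chain carbon bound to an oxygen next to a carbonyl group gave a modestly higher number in this assay.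

The next compound, compound 3 `COc1ccc(OC)c(C(=O)/C=C/c2ccc(C(=O)NC(C)C)cc2)c1`, differs from compound 2 by isopropylamino in place of benzyloxy on a carbonyl carbon. For the measured compounds named here, no measured step swaps an ester for an amide, so the single step available bears on it only loosely: it suggests that the larger benzyloxycarbonyl end is the less favourable of the two measured, and compound 3 removes that benzyloxy group entirely while adding an isopropylamino group of smaller size. Going by these compounds, the step of a 2.3-fold lower number from compound 2 to compound 3 (0.35 log units; beyond the scatter) is therefore expected to run toward a lower number, though with wide uncertainty since the amide itself is untested. Compound 3 is estimated at 8000 nM, within 2500 nM to 25000 nM.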

Compound 3, half-maximal inhibitory concentration: 1580 nM
For compound 3 the middle estimate is 5.1-fold (0.70 log units) above the measured one, and the stated range ends above it.
By their numbers in this assay, from the lowest: compound 3; then compound 1; then compound 2.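

Among the compounds shown here, on the carbonyl carbon, the group attached now clearly matters to more than the ester alone: in this assay, isopropylamino in place of benzyloxy gives an 11-fold lower number from compound 2 to compound 3 (1.06 log units; beyond the scatter) and is the largest step so far. Isopropylamino in place of methoxy gives a 3.1-fold lower number from compound 1 to compound 3 (0.49 log units; beyond the scatter) and so places the amide below both esters, which shows that removing the benzyloxy ring does not account for the whole change and that the order does not simply track the size of this group. Nothing available accounts for this order.

The change replaces the ester oxygen with a nitrogen bearing the amide hydrogen and also introduces the branched isopropyl group, and the compounds shown do not separate these two features. A dimethylamino group, which has no amide hydrogen, and a straight propylamino chain on the same carbonyl carbon would bear on that question, while a carboxylic acid there remains an open comparison.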